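Swapping the chlorine's ring partner in compound 1

The source may report more compounds than this note shows. Statements on the series, on what has been measured and on what is new or still open speak of the compounds shown alone.

Of the compounds shown here, three with a shared core have been measured in an assay on HEK293 cells for positive allosteric modulation of metabotropic glutamate receptor 2 (Rattus norvegicus), read by thallium flux, with a stated time of 2.5 min; on this read-out lower numbers stand for smaller maximal responses and higher numbers for larger maximal responses. Compound 1 `Cc1c(OCCCCOc2ccc(C(=O)O)cc2Cl)ccc(C(=O)CC2CCCC2)c1O` gives 82.2%, the highest of the three numbers. Compound 3 `Cc1c(OCCCCOc2ccc(C(=O)C(C)C)c(O)c2C)cccc1C(=O)O` gives 66.9%, which sits below compound 1 by more than the usual scatter. Compound 2 `COC(=O)c1ccc(OCCCCOc2ccc(C(=O)CC3CCCC3)c(C)c2C)cc1` gives 14.1%, far below compound 1.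

Compound 4 `Cc1c(OCCCCOc2ccc(C(=O)O)c(Cl)c2)ccc(C(=O)CC2CCCC2)c1O` has not yet been measured in this assay. It contains the same atoms as compound 1, joined differently: 4-carboxy-3-chlorophenyl in place of 4-carboxy-2-chlorophenyl on an oxygen on a saturated carbon. The 4-carboxy-3-chlorophenyl group thus replaces the 4-carboxy-2-chlorophenyl group on an oxygen on a saturated carbon, and nothing else changes.

For the measured compounds named here, no pair of measured compounds differs in just one place, so there is no measured step to lean on. With the carboxylic acid kept and only the chlorine's place on that ring altered, the expected step from compound 1 to compound 4 is a number 8.2 percentage points lower from compound 1 to compound 4 (within the scatter), a small drop that stays within the scatter. Compound 4 is therefore estimated at 74%, with a range from 50% to 95%.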

Compound 4, largest response reached (reported as percent of maximum), in percent of the reference or control that the assay uses: 80.8%
Compound 4: middle estimate off by 6.8 percentage points, on the low side, and the stated range covers the measured number.
By their numbers in this assay, from the lowest: compound 2; then compound 3; then compounds 4 and 1 (each within the scatter of the next).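

Moving the chlorine gives the first comparison here in which only one place differs, and in this assay the swap of 4-carboxy-2-chlorophenyl for 4-carboxy-3-chlorophenyl on an oxygen on a saturated carbon is a number 1.4 percentage points lower from compound 1 to compound 4 (within the scatter). This read-out therefore does not separate these two chlorine placements, so on this ring, with the carboxylic acid kept, the shift of the chlorine leaves the maximal response unchanged within the usual scatter. No measurement at hand speaks to why the two placements read alike.

Still open, as far as these compounds go, is what this ring would give with no chlorine at all, or with a bromine or a methyl group in its place. Also open, from the compounds shown here alone, is whether a tetrazole could stand in for the carboxylic acid with either chlorine placement.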